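A few compounds are considered here, and "the series" means these few. Any claim that something is new, unique, unknown or untested is made for them only; others in the source may bear on it.

Compound 3 `CN(C)C(=O)N1CCN([C@H]2CC[C@H](Nc3ncnc4[nH]cc(C5CCOCC5)c34)CC2)CC1` gives 13 uL/min in an ADME assay on cells (Hepatocyte, Rattus norvegicus) for metabolic stability; a higher number here means faster removal of the compound, a lower number slower removal. Among the three numbers measured so far it stands second highest: compound 2 `CC(=O)N1CCN([C@H]2CC[C@H](Nc3ncnc4[nH]cc(C5CCOCC5)c34)CC2)CC1` gives 4.6 uL/min in this assay, and compound 1 `CN(C)[C@H]1CC[C@H](Nc2ncnc3[nH]cc(C4CCCC4)c23)CC1`, which carries a different group on the ring carbon and a dimethylamino group instead of the piperazine, gives 71 uL/min. Among the compounds with values here, the only single-point step at the piperazine nitrogen is a 2.8-fold higher number from compound 2 to compound 3 (0.45 log units; beyond the scatter); this is the sole measured step that bears on changes at this position.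

Compound 4 `CS(=O)(=O)N1CCN([C@H]2CC[C@H](Nc3ncnc4[nH]cc(C5CCOCC5)c34)CC2)CC1` is the next variation at that nitrogen: methylsulfonyl in place of dimethylcarbamoyl on an amine nitrogen in a ring. Within the data shown here, no measured pair covers a methylsulfonyl group, so the expectation rests on the size of the acetyl-to-dimethylcarbamoyl step alone, which was modest. A change of similar or smaller magnitude, more likely downward than upward, is expected in this assay, and a result within the scatter of compound 3 would not be surprising. Compound 4 is therefore expected to give 9 uL/min, with a range from 4 uL/min to 20 uL/min. The expected step is a 1.4-fold lower number from compound 3 to compound 4 (0.16 log units; within the scatter).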

Compound 4, intrinsic clearance in a liver preparation (reported as CLH), per the amount of preparation that the assay uses: 16 uL/min
For compound 4 the middle estimate is 1.8-fold (0.25 log units) below the measured one; the measured number falls inside the stated range.
By their numbers in this assay, from the lowest: compound 2; then compounds 3 and 4 (each within the scatter of the next); then compound 1.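

In this assay, methylsulfonyl in place of dimethylcarbamoyl on the amine nitrogen in the ring gives a 1.2-fold higher number from compound 3 to compound 4 (0.09 log units; within the scatter) and so does not separate these two groups. Methylsulfonyl in place of acetyl gives a 3.5-fold higher number from compound 2 to compound 4 (0.54 log units; beyond the scatter) and lands close to the earlier step of a 2.8-fold higher number from compound 2 to compound 3 (0.45 log units; beyond the scatter) in size, so among the three groups shown at this position, only the acetyl group of compound 2 stands apart, with the lowest number. Nothing at hand bears on why the acetyl compound differs from the other two.

Going by these compounds, it remains open whether the low number is particular to acetyl or extends to a longer acyl chain such as propionyl, or to a plain methyl on this nitrogen. A free secondary amine at the same place is also untested in the compounds shown.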